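A few compounds are considered here, and "the series" means these few. Any claim that something is new, unique, unknown or untested is made for them only; others in the source may bear on it.

compound 1 `C[C@H](NC(=O)c1cccc(F)c1)c1ccc(NC(=O)N2CC(c3ccc(N)nc3)C2)cc1`: 7.6 nM
compound 2 `C[C@H](NC(=O)c1ncccn1)c1ccc(NC(=O)N2CC(c3ccc(N)nc3)C2)cc1`: 68 nM
compound 3 `C[C@H](NC(=O)[C@@H]1CCCN1C)c1ccc(NC(=O)N2CC(c3ccc(N)nc3)C2)cc1`: not yet measured

In a functional assay on A2780 cells (Homo sapiens) for antiproliferative activity, read by CellTiter-Glo, with a stated time of 72 h (a lower number here means a stronger inhibitor, a higher number a weaker inhibitor), compound 2 gives 68 nM, the higher of the two numbers and so the weaker result. Compound 3 differs from it as follows: 1-methylpyrrolidin-2-yl in place of pyrimidin-2-yl on a carbonyl carbon. That is, 1-methylpyrrolidin-2-yl stands in place of pyrimidin-2-yl on a carbonyl carbon, and the aromatic ring gives way to a non-aromatic one. Within the data shown here, only one measured step bears on this place: an 8.9-fold higher number from compound 1 to compound 2 (0.95 log units; beyond the scatter). Among the measured compounds shown here, it shows that a swap of the group on this carbonyl carbon can move the number by a modest amount, but no measured compound carries a non-aromatic ring here, so direction remains uncertain. For the measured compounds named here, a modest rise in this assay is the working expectation, no larger than that step. The estimated change is a 2.5-fold higher number from compound 2 to compound 3 (0.40 log units; beyond the scatter). Compound 3 is expected at 170 nM, within an estimated range of 40 nM to 600 nM.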

Compound 3, half-maximal inhibitory concentration: 11 nM
Estimate against measurement, compound 3: 15-fold (1.19 log units) above; the whole stated range lies above it.
By their numbers in this assay, from the lowest: compounds 1 and 3 (each within the scatter of the next); then compound 2.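

In this assay, the first non-aromatic ring at this carbonyl carbon gives a 6.2-fold lower number from compound 2 to compound 3 (0.79 log units; beyond the scatter) on replacing pyrimidin-2-yl with 1-methylpyrrolidin-2-yl, so an aromatic ring is not required here for a low number. Against 3-fluorophenyl, the same group gives a 1.4-fold higher number from compound 1 to compound 3 (0.16 log units; within the scatter) and the two groups are not separated, leaving pyrimidin-2-yl as the one group of the three that stands apart from both others. Nothing measured accounts for these steps.

Open, as far as these compounds go, is whether the ring nitrogen of 1-methylpyrrolidin-2-yl and its methyl group matter, which cyclopentyl and pyrrolidin-2-yl on the same carbonyl carbon would address. Also open, from the compounds shown here alone, are the opposite configuration at the stereocentre of this ring and an open-chain amine such as dimethylaminomethyl in its place.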